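Swapping the aryl group on the piperazine nitrogen for a pyridine

The source may report more compounds than this note shows. Statements on the series, on what has been measured and on what is new or still open speak of the compounds shown alone.

Of the compounds shown here, three sharing one core have been tested in an assay on HEK293 cells for inhibition of Voltage-dependent T-type calcium channel subunit alpha-1G (Homo sapiens), read by fluorescence, tested at 10 uM; a higher number here means more inhibition at the concentration tested (going by the name of the read-out), a lower number less inhibition: compound 1 `CCCc1nc(-c2ccccc2)c(CNCCN2CCN(c3cccc(C)c3)CC2)o1` gives 43.1%, compound 2 `CCCc1nc(-c2ccccc2)c(CNCCN2CCN(c3cccc(C)c3C)CC2)o1` gives 66.7%, and compound 3 `CCCc1nc(-c2ccccc2)c(CNCCN2CCN(c3cccc(Cl)c3)CC2)o1` gives 51.2%. Compound 3 stands second of the three, its gap to compound 1 within the scatter, its gap to compound 2 beyond it. Compound 4 `CCCc1nc(-c2ccccc2)c(CNCCN2CCN(c3ccccn3)CC2)o1` differs from compound 3 by pyridin-2-yl in place of 3-chlorophenyl on an amine nitrogen in a ring. Going by the values given here, the only step that changes the same group is a number 15.5 percentage points lower from compound 2 to compound 3 (beyond the scatter), a modest drop on losing the two methyl groups. Removing the chlorine and adding the ring nitrogen is expected to pull in the same direction, so compound 4 is estimated at 35%, with a range from 15% to 58%, a step of a number 16.2 percentage points lower from compound 3 to compound 4 (beyond the scatter).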

Compound 4, a percentage reported as inhibition, at one concentration (the size of the read-out at that concentration, not a potency): 48.1%
Estimate against measurement, compound 4: 13.1 percentage points below; the range from low to high includes it.
By their numbers in this assay, from the lowest: compounds 1, 4 and 3 (each within the scatter of the next); then compound 2.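

On this nitrogen, an unsubstituted pyridin-2-yl ring, with its hydrogen-bond acceptor, performs much like the singly substituted phenyl rings: the change is a number 3.1 percentage points lower from compound 3 to compound 4 (within the scatter), and replacing 3-methylphenyl gives a number 5 percentage points higher from compound 1 to compound 4 (within the scatter). Compound 2 alone stands clear of this group, since replacing its 2,3-dimethylphenyl gives a number 18.6 percentage points lower from compound 2 to compound 4 (beyond the scatter). No measurement here explains these differences. On these data alone, whether a methyl group on the pyridine ring would recover the level of compound 2 remains open. So does the effect of a pyrimidine ring or a methoxy group on the phenyl ring.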